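This account rests on a few compounds, and the source may have more. Where it says the series, first, only, none or still open, it means among the compounds named here.

The measured compounds are compound 1 `CC/C=C/C(=O)Nc1cc2c(N3CCc4ccccc43)ncnc2cc1OC` with 2470 nM, compound 2 `CCC/C=C/C(=O)Nc1cc2c(N3CCc4ccccc43)ncnc2cc1OC` with 2920 nM, and compound 3 `CC/C=C/C(=O)Nc1cc2c(N3CCCc4ccccc43)ncnc2cc1O[C@@H]1CCOC1` with 14100 nM, all in a functional assay on A549 cells (Homo sapiens) for antiproliferative activity, read by MTT assay, with a stated time of 72 h; on this read-out higher numbers stand for weaker inhibition and lower numbers for stronger inhibition.

Compound 1 and compound 2 share a core and differ only in the side chain of the amide: methyl in place of hydrogen on a saturated chain carbon, two bonds along the chain from a double-bonded chain carbon. In this assay that change gives a 1.2-fold higher number from compound 1 to compound 2 (0.07 log units; within the scatter), so the two numbers cannot be told apart. Compound 3 carries a different core, and the difference between the two cores is not broken down here. Compound 3 gives the highest number of the three, with compound 2 nearest and compound 1 furthest, both gaps beyond the scatter.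

Compound 4 `CC(C)/C=C/C(=O)Nc1cc2c(N3CCCc4ccccc43)ncnc2cc1O[C@@H]1CCOC1` is not yet measured. It differs from compound 3 in the same side chain: methyl in place of hydrogen on a saturated chain carbon bound to a double-bonded chain carbon and a saturated chain carbon. This is the same kind of change as the step from compound 1 to compound 2, but not the same, since there the methyl enters on a saturated chain carbon two bonds along the chain from a double-bonded chain carbon, whereas here it enters on a saturated chain carbon bound to a double-bonded chain carbon and a saturated chain carbon. Among the measured compounds shown here, the closest measured precedent is the step from compound 1 to compound 2, which stayed within the scatter, so for compound 4 the expected step is a 1.1-fold higher number from compound 3 to compound 4 (0.03 log units; within the scatter), because compound 3 gives 14100 nM and the one comparable change altered little. Compound 4 is therefore estimated at 15000 nM, with a range from 6000 nM to 40000 nM.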

Compound 4, half-maximal inhibitory concentration: 6820 nM
Compound 4: middle estimate off by 2.2-fold (0.34 log units), on the high side; the measured number falls inside the stated range.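

In this assay, the methyl on the saturated chain carbon bound to a double-bonded chain carbon and a saturated chain carbon gives a 2.1-fold lower number from compound 3 to compound 4 (0.32 log units; beyond the scatter), a modest step that turns ethyl into isopropyl on the core of compound 3. Set beside the earlier step on the core of compound 1, it does not stand apart by more than two such steps can scatter: the same change on two cores in this assay, a 1.2-fold higher number (0.07 log units; within the scatter) from compound 1 to compound 2 and a 2.1-fold lower number (0.32 log units; beyond the scatter) from compound 3 to compound 4, 2.4-fold (0.39 log units) apart, within the scatter of two such steps. This shows no effect of the core on the change, yet it does not show that the change carries over unaltered, since each core offers a single pair and the methyl enters at a different place in each, two bonds along the chain from a double-bonded chain carbon in compound 2 but on the carbon bound to a double-bonded chain carbon and a saturated chain carbon in compound 4.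

The compounds shown leave open how the 3-methylbut-1-en-1-yl side chain would read on the core of compound 1, which would put the methyl at the same place on both cores. They also leave open how the series would respond to a longer chain or to a side chain carrying an amine.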